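This account rests on a few compounds, and the source may have more. Where it says the series, first, only, none or still open, it means among the compounds named here.

Compound 1 `CCCSc1nc(N/N=C(\C)c2ccccc2O)c2nnn(Cc3ccc(Cl)cc3)c2n1` carries a propylsulfanyl group and a 4-chlorobenzyl group on the shared core. In a functional assay on MCF7 cells (Homo sapiens) for antiproliferative activity, read by MTT assay, with a stated time of 72 h (a higher number here means a weaker inhibitor, a lower number a stronger inhibitor), compound 1 gives 42600 nM, the highest of the two numbers reported in this series. Compound 3 `C/C(=N\Nc1nc(SCc2ccccc2)nc2c1nnn2Cc1ccccc1)c1ccccc1O`, which has a benzylsulfanyl group in place of the propylsulfanyl group and an unsubstituted benzyl group, gives 950 nM in this assay; the gap between compound 1 and compound 3 lies beyond the scatter of repeated measurements. Compound 2 `CCCSc1nc(N/N=C/c2ccc(Cl)cc2)c2nnn(Cc3ccccc3)c2n1` reaches only the limit of this assay, at > 64000 nM, so no number is known for it; this is the limit of > 64000 nM in this assay, at which 1 of the 3 values shown sits.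

Compound 4 `CCCSc1nc(N/N=C(\C)c2ccccc2O)c2nnn(Cc3cccc(Cl)c3)c2n1` has not yet been measured in this assay. It differs from compound 1 in one place: 3-chlorophenyl in place of 4-chlorophenyl on a saturated chain carbon bound to an aromatic nitrogen. Within the data shown here, no measured step moves the chlorine substituent around the benzyl ring, so the size of this step cannot be read from the data. The change keeps the atom count, the ring and the substituent, so the step from compound 1 to compound 4 is expected to be small, within or near the scatter, with no clear direction, namely a 1.1-fold lower number from compound 1 to compound 4 (0.05 log units; within the scatter). For compound 4 the estimated value in this assay is 38000 nM, with a range from 12000 nM to 100000 nM.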

Compound 4, half-maximal inhibitory concentration: 39900 nM
Compound 4: the middle estimate sits 1.1-fold (0.02 log units) below what was measured, within the range that was stated.
By their numbers in this assay, from the lowest: compound 3; then compounds 4 and 1 (each within the scatter of the next). At a limit, above all of these: compound 2.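

In this assay, the change from 4-chlorobenzyl to 3-chlorobenzyl on a saturated chain carbon bound to an aromatic nitrogen gives a 1.1-fold lower number from compound 1 to compound 4 (0.03 log units; within the scatter). Among these compounds, this is the only single-place step so far, and it shows that, with the propylsulfanyl group and the rest of compound 1 held constant, these two chlorine placements on the benzyl ring cannot be told apart in this read-out. No measured property in the data bears on this step, so it can be recorded only as a size.

The pair says nothing about whether the chlorine itself matters, since no step shown sets a chlorobenzyl group against an unsubstituted benzyl group with all else equal, and it remains open whether a fluorine or a methoxy group at this place would also stay within the scatter of compound 1. As far as these compounds go, it is also open whether the same chlorine shift would stay as small with a benzylsulfanyl group in place of the propylsulfanyl group.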